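From Butyl to Pentyloxy on a Shared Core

This account rests on a few compounds, and the source may have more. Where it says the series, first, only, none or still open, it means among the compounds named here.

Compound 1 `Nc1nc(O)nc2c1nc(O)n2Cc1ccccc1` and compound 2 `CCCCc1nc(N)c2nc(O)n(Cc3ccccc3)c2n1` share a core and differ at a single aromatic carbon. In a functional assay (spleen, spleen) for activation, with Mus musculus as the target (a lower number here means that less compound is needed, a higher number that more compound is needed for the effect), compound 1 gives 0.1 uM and compound 2 gives 0.03 uM, the lowest of the two numbers; the step between them is a 3.3-fold lower number from compound 1 to compound 2 (0.52 log units; beyond the scatter). Compound 3 `CCCCCOc1nc(N)c2nc(O)n(Cc3ccccc3)c2n1` is the unmeasured analogue: pentyloxy in place of butyl on an aromatic carbon. Among the compounds with values here, the one measured step exchanged hydroxy for butyl and was modest; it offers no direct guide for a pentyloxy chain, so only a small move in either direction is expected. Compound 3 is expected to give 0.02 uM, within 0.005 uM to 0.08 uM. The expected step is a 1.5-fold lower number from compound 2 to compound 3 (0.18 log units; within the scatter).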

Compound 3, minimum effective concentration: 0.01 uM
Beside the measured number, compound 3's estimate is 2.0-fold (0.30 log units) above it, within the range that was stated.
By their numbers in this assay, from the lowest: compound 3; then compound 2; then compound 1.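

In this assay, this aromatic carbon between two ring nitrogen atoms proves to have room for further change after butyl, as pentyloxy lowers the number again (a 3.0-fold lower number from compound 2 to compound 3 (0.48 log units; beyond the scatter)). Measured against the hydroxy compound, pentyl on that oxygen gives the largest step among the three compounds (a 10-fold lower number from compound 1 to compound 3 (1.00 log units; beyond the scatter)). Nothing available here explains either step.

The compounds shown leave open whether the oxygen or the chain length carries the change, which butoxy or plain pentyl on the same carbon would separate. From the compounds shown here alone, how a hexyloxy chain or an amine there would read also remains open.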